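Para-substituent changes on the sulfonamide aryl ring

The source may report more compounds than this note shows. Statements on the series, on what has been measured and on what is new or still open speak of the compounds shown alone.

compound 1: `Cc1ccc(S(=O)(=O)N(C)c2ccc3[nH]c(-c4n[nH]c5ccccc45)cc3n2)cc1` — 13300 nM
compound 2: `CN(c1ccc2[nH]c(-c3n[nH]c4ccccc34)cc2n1)S(=O)(=O)c1ccc(Cl)cc1` — 5980 nM
compound 3: `CN(c1ccc2[nH]c(-c3n[nH]c4ccccc34)cc2n1)S(=O)(=O)c1ccc(Br)cc1` — 9850 nM

In a functional assay on HCT-116 cells (Homo sapiens) for antiproliferative activity, read by MTT assay, with a stated time of 72 h (on this read-out higher numbers stand for weaker inhibition and lower numbers for stronger inhibition), compound 3 stands second highest of the three numbers. Its nearest neighbour is compound 1 with 13300 nM and its furthest is compound 2 with 5980 nM. Compound 4 `COc1ccc(S(=O)(=O)N(C)c2ccc3[nH]c(-c4n[nH]c5ccccc45)cc3n2)cc1` differs from compound 3 by methoxy in place of bromo on an aromatic carbon. Every measured step touches the same aromatic carbon and all are small: a 1.4-fold lower number from compound 1 to compound 3 (0.13 log units; within the scatter), a 1.6-fold higher number from compound 2 to compound 3 (0.22 log units; within the scatter) and a 2.2-fold lower number from compound 1 to compound 2 (0.35 log units; beyond the scatter). For the measured compounds named here, no measured step swaps a halogen for methoxy, so the direction rests on those modest exchanges only; a step within the scatter, perhaps slightly higher, is expected in this assay. Compound 4 is therefore estimated at 11500 nM, range 5000 nM to 26000 nM. That estimate means an expected step of a 1.2-fold higher number from compound 3 to compound 4 (0.07 log units; within the scatter).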

Compound 4, half-maximal inhibitory concentration: 22400 nM
For compound 4 the middle estimate is 1.9-fold (0.29 log units) below the measured one; the measured number falls inside the stated range.
By their numbers in this assay, from the lowest: compounds 2, 3, 1 and 4 (each within the scatter of the next, the first and the last beyond it).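

On this aromatic carbon in this assay, methoxy separates from both halogens, with a 2.3-fold higher number from compound 3 to compound 4 (0.36 log units; beyond the scatter) and a 3.7-fold higher number from compound 2 to compound 4 (0.57 log units; beyond the scatter), each beyond the scatter. Against methyl there is no such separation: a 1.7-fold higher number from compound 1 to compound 4 (0.23 log units; within the scatter) lies within the scatter, so these two groups cannot be ordered here. No evidence on the origin of these modest steps is available.

On these data alone, whether an amine, a carboxylic acid or a longer chain on this carbon would give a lower number than compound 2 remains open. Also open, as far as these compounds go, is whether the methoxy step would hold with a different group on the sulfonamide nitrogen.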